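A few compounds are considered here, and "the series" means these few. Any claim that something is new, unique, unknown or untested is made for them only; others in the source may bear on it.

Measured compounds:
compound 1 `COc1cc(C)cc(-c2c(-c3ccnc(-c4ccc(C(C)=O)cc4)c3)cnn2CC#N)c1` — 84%
compound 2 `COc1cc(C)cc(-c2nn(CC#N)cc2-c2ccc(-c3cccc(C(C)=O)c3)nc2)c1` — 84%

Of the compounds shown here, two sharing the same core have been tested in a functional assay on HOP-92 cells (Homo sapiens) for cytotoxicity, read by sulforhodamine B assay, with a stated time of 48 h, tested at 0.001 uM; a higher number here means a weaker effect of the compound at the concentration tested, a lower number a stronger effect. Compound 1 gives 84% in this assay, and compound 2 gives 84%. The two values are level at the digits shown, and their difference lies within the usual scatter of such measurements, so nothing can be said about one being stronger than the other; both show only a weak effect at the concentration tested.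

The next compound to be measured is compound 3 `COc1cc(C)cc(-c2c(-c3ccnc(-c4ccc(N(C)C)cc4)c3)cnn2CC#N)c1`. It differs from compound 1 in a single place:

dimethylamino in place of acetyl on an aromatic carbon

Within the data shown here, no step between two measured compounds touches this position, so the data give no guide to the size or direction of the change. With both measured values sitting close together and high, the step from compound 1 to compound 3 in this assay is expected to be small, within the scatter, and of no clear direction. For compound 3 the expected value in this assay is 85%, with a range from 65% to 100%, which corresponds to an expected step of a number 1 percentage points higher from compound 1 to compound 3 (within the scatter).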

Compound 3, a percentage reported as activity, at one concentration (the size of the read-out at that concentration, not a potency): 26%
The estimate for compound 3 lay 59 percentage points above the measured number; measured number below the stated range.
By their numbers in this assay, from the lowest: compound 3; then compounds 1 and 2 (each within the scatter of the next).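

In this assay, dimethylamino in place of acetyl on an aromatic carbon para to a large group gives a number 58 percentage points lower from compound 1 to compound 3 (beyond the scatter). Among these compounds, this is the first step at this position, and it shows that the group carried by this six-membered aromatic ring can change the read-out strongly at the concentration tested, even though the leaving and entering groups match in their counts of heavy atoms, hydrogen-bond donors and hydrogen-bond acceptors; the difference in the read-out therefore goes with the exchange of the groups themselves, not with any change in those counts. Nothing measured here explains why this exchange has so large an effect.

Going by these compounds, it remains open whether the effect belongs to dimethylamino in particular or would also appear with another group at this position, such as a primary amine, a methoxy group, a morpholine ring or a longer dialkylamino chain. Also open, on these data alone, is whether the same exchange would have a similar effect on the acetyl-bearing ring of compound 2, and since each read-out comes from a single concentration, none of these values gives a potency.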